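Replacing Iodine with an Ethoxyphenyl Group on a Fused Core

The compounds below may be only part of what the source reports. "The series", "measured", "known", "first", "only" and "open" are said of these compounds alone.

Of the compounds shown here, three sharing one fused core have been measured in an assay on cells for displacement of a labelled ligand from Orexin/Hypocretin receptor type 1 (Homo sapiens), read by scintillation counting, with stated times of 10 min and 90 min, tested at 10 uM; a lower number here means less inhibition, a higher number more inhibition at the concentration tested (going by the name of the read-out). Compound 1 `COC(=O)c1ccc2ccc(C(=O)c3ccccc3)c-2cc1` gives 7.2%. Compound 2 `COC(=O)c1ccc2c(C(=O)c3ccccc3)cc(C(=O)c3ccccc3)c-2cc1` gives -10.6%. Compound 3 `COC(=O)c1ccc2c(I)cc(C(=O)c3ccccc3)c-2cc1` gives -34.9%, the lowest of the three numbers: it sits a number 24.3 percentage points lower from compound 2 to compound 3 (beyond the scatter) and a number 42.1 percentage points lower from compound 1 to compound 3 (beyond the scatter), and both of these steps lie beyond the scatter.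

Compound 4 `CCOc1ccc(-c2cc(C(=O)c3ccccc3)c3ccc(C(=O)OC)ccc2-3)cc1` has not yet been measured in this assay. Its change from compound 3 is 4-ethoxyphenyl in place of iodo on an aromatic carbon. Within the data shown here, the steps that bear on it are those leading into compound 3: putting iodo in place of hydrogen gave a number 42.1 percentage points lower from compound 1 to compound 3 (beyond the scatter), and putting iodo in place of benzoyl gave a number 24.3 percentage points lower from compound 2 to compound 3 (beyond the scatter). Both show that the iodo-bearing compound gives the lowest number, so removing iodo in favour of a group that, like benzoyl, carries a six-membered aromatic ring of carbon only is expected to move the number back up. A step of about a number 26.9 percentage points higher from compound 3 to compound 4 (beyond the scatter) is expected, in the upward direction. Compound 4 is therefore estimated at -8%, with a range from -32% to 16%.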

Compound 4, a percentage reported as inhibition, at one concentration (the size of the read-out at that concentration, not a potency): 8.4%
For compound 4 the middle estimate is 16.4 percentage points below the measured one; the range from low to high includes it.
By their numbers in this assay, from the lowest: compound 3; then compound 2; then compounds 1 and 4 (each within the scatter of the next).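

In this assay, the position on the five-membered aromatic ring responds strongly to what it carries: 4-ethoxyphenyl in place of iodo gives a number 43.3 percentage points higher from compound 3 to compound 4 (beyond the scatter), and 4-ethoxyphenyl in place of benzoyl gives a number 19 percentage points higher from compound 2 to compound 4 (beyond the scatter), so two groups that each carry a six-membered aromatic ring of carbon only do not read alike here. 4-ethoxyphenyl in place of hydrogen gives a number 1.2 percentage points higher from compound 1 to compound 4 (within the scatter), so this large group cannot be told apart from a bare hydrogen at this position, whereas benzoyl and iodo both read lower than hydrogen. Nothing available explains these differences.

Still open, as far as these compounds go, is what the ethoxy contributes on its own, which a plain phenyl at this position would show, and how an amine or a carboxylic acid on that ring would read. These readings come from a single concentration, so they say nothing about potency.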